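The compounds below may be only part of what the source reports. "The series", "measured", "known", "first", "only" and "open" are said of these compounds alone.

Measured compounds:
compound 1, `COc1ccc(-c2nc3cc(Cl)c(Cl)cc3[nH]2)c(N)c1` — 6500 nM
compound 2, `O=C(CN1CCN(c2ccccc2)CC1)Nc1ccc(-c2nc3cc(C(F)(F)F)ccc3[nH]2)cc1` — 32000 nM
compound 3, `CCC(=O)Nc1ccc(-c2nc3cc(C(F)(F)F)ccc3[nH]2)cc1` — limit of > 100000 nM

In an ADME assay on MDBK cells (Bos taurus) for cytotoxicity, read by MTT assay, with a stated time of 96 h (a lower number here means that less compound is tolerated, a higher number that more compound is tolerated), compound 1 gives 6500 nM, the lowest of the two numbers in hand, so of these it is the compound of which least is tolerated. Compound 2 gives 32000 nM in this assay, a higher number that lies beyond the usual scatter from compound 1. For compound 3 only a limit is reported in this assay, > 100000 nM, which is the limit of > 100000 nM in this assay, at which 1 of the 3 values shown sits, rather than a measured number. Among the measured compounds shown here, none of the three pairs differs in a single place, so no step between measured compounds can be set down.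

Compound 4, `COc1ccc(-c2nc3cc(Cl)c(Cl)cc3[nH]2)c([N+](=O)[O-])c1`, shares its core with compound 1 and differs from it in one place: nitro in place of amino on an aromatic carbon. For the measured compounds named here, no measured step with this change is available, and the two compounds with a related core, compound 2 and compound 3, differ from compound 1 in several places at once, so they do not show what the change does on its own. Compound 4 is therefore expected to stay close to compound 1 in this assay, with a step from compound 1 to compound 4 of a 1.2-fold higher number from compound 1 to compound 4 (0.09 log units; within the scatter), not beyond the scatter. The estimate for compound 4 in this assay is 8000 nM, in a range from 2500 nM to 30000 nM.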

Compound 4, half-maximal cytotoxic concentration: 28000 nM
Compound 4: middle estimate off by 3.5-fold (0.54 log units), on the low side, and the stated range covers the measured number.
By their numbers in this assay, from the lowest: compound 1; then compounds 4 and 2 (each within the scatter of the next). At a limit, above all of these: compound 3.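

Among the compounds shown here, the step of a 4.3-fold higher number from compound 1 to compound 4 (0.63 log units; beyond the scatter) in this assay is the first comparison here that isolates a single change, nitro in place of amino on an aromatic carbon, ortho to a large group and meta to a methoxy group. It shows that this position is not silent in the assay: the change on its own moves the number beyond the scatter, towards more compound being tolerated, which compounds 2 and 3 could not show as they differ from compound 1 in several places at once. The change removes the hydrogen-bond donor of the amino group while adding heavy atoms and hydrogen-bond acceptors, and this single pair cannot separate these differences from one another.

Going by these compounds, whether a plain hydrogen, a methyl group or a carboxylic acid on this aromatic carbon would sit with compound 1 or with compound 4 remains open, as does whether the same change would move the number on the core of compound 3. Nothing in hand gives a cause for the step.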